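This account rests on a few compounds, and the source may have more. Where it says the series, first, only, none or still open, it means among the compounds named here.

Compound 1, whose structure is `CC(NC(=O)N(C)S(=O)(=O)c1ccccc1)c1ccccc1OCc1ccccc1`, was tested in a functional assay on thoracic aorta (Rattus norvegicus, strain Wistar), with a stated time of 15 min (on this read-out higher numbers stand for an effect only at larger amounts of compound and lower numbers for an effect already at smaller amounts), and gave 21700 nM. Compound 2, whose structure is `CC(NC(=O)NS(=O)(=O)c1ccccc1)c1ccccc1OCc1ccccc1`, reached only a limit of this assay, recorded as > 200000 nM, and not a number. The change between them is hydrogen in place of methyl on an amide-type nitrogen, and it produced an at least 9.2-fold higher number from compound 1 to compound 2 (0.96 log units; beyond the scatter). Compound 3, whose structure is `Cc1ccc(OCc2ccccc2)c(C(C)NC(=O)N(C)S(=O)(=O)c2ccccc2)c1`, gave 68200 nM in this assay; its core differs from that of compound 1 by methyl in place of hydrogen on an aromatic carbon, and the step was a 3.1-fold higher number from compound 1 to compound 3 (0.50 log units; beyond the scatter). Compound 3 thus holds the highest of the two numbers actually read in this assay, while the value of compound 2 sits at the limit of > 200000 nM in this assay, at which 1 of the 3 values shown sits.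

Compound 4, whose structure is `Cc1ccc(OCc2ccccc2)c(C(C)NC(=O)NS(=O)(=O)c2ccccc2)c1`, has not yet been measured. It differs from compound 3 by hydrogen in place of methyl on an amide-type nitrogen, the same change that turned compound 1 into compound 2, made here on the core of compound 3 that carries the extra methyl. Since compound 3 already gives 68200 nM and the earlier change gave an at least 9.2-fold higher number from compound 1 to compound 2 (0.96 log units; beyond the scatter), the step from compound 3 to compound 4 is expected to be at least as large, estimated as a 9.2-fold higher number from compound 3 to compound 4 (0.97 log units; beyond the scatter). On that basis compound 4 is expected to give roughly 630000 nM in this assay, somewhere between 200000 nM and 2000000 nM, with a strong chance that only a limit and no number is reported.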

Compound 4, half-maximal effective concentration: > 200000 nM
Compound 4 ended at the assay's limit; the forecaster's own chance of this, stated with the estimate: 85%; the middle value does not contradict the limit.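

In this assay compound 4 stops at a limit of the assay, > 200000 nM, and gives no number. Hydrogen in place of methyl on the amide-type nitrogen gives an at least 2.9-fold higher number from compound 3 to compound 4 (0.46 log units; beyond the scatter), so on both cores shown the change moves the read-out the same way, and beyond the scatter: the same change on two cores in this assay, an at least 9.2-fold higher number (0.96 log units; beyond the scatter) from compound 1 to compound 2 and an at least 2.9-fold higher number (0.46 log units; beyond the scatter) from compound 3 to compound 4; the limit leaves it open whether they differ This shows that the direction carries over from the core of compound 1 to the core of compound 3, but it does not show that the size carries over, since each step is only a lower bound and the true gap could be much the same or quite different on the two cores; the step between compound 2 and compound 4 cannot be read, as both ends are limits.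

The compounds shown leave open whether a longer chain such as ethyl or propyl on that nitrogen would behave like methyl or like hydrogen. They also leave open how a chlorine or methoxy group in place of the methyl on the aromatic carbon would change the number, and whether the change on the nitrogen would then run the same way.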